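A few compounds are considered here, and "the series" means these few. Any claim that something is new, unique, unknown or untested is made for them only; others in the source may bear on it.

Measured compounds:
- compound 1, `CC(=O)SCC(=O)c1ccc(NS(=O)(=O)c2ccc(OCCc3ccccn3)cc2)nc1`, in a functional assay on U226 cells (Homo sapiens) for cytotoxicity (a lower number here means that less compound is needed, a higher number that more compound is needed for the effect), gives 9600 nM
- compound 2, `CC(=O)SCC(=O)c1ccc(NS(=O)(=O)c2ccc(OC3CCCN(C)C3)cc2)nc1`, in this assay gives 1200 nM
- compound 3, `CC(=O)SCC(=O)c1ccc(NS(=O)(=O)c2ccc(OCc3ccccn3)cc2)nc1`, in this assay gives "not determined" (no result reported)

All three share one core; they differ only in the group attached to the oxygen on the aromatic ring. Compound 3 therefore stands without a number of its own, and its closest measured neighbour is compound 1, which carries the same pyridin-2-yl end on a chain one carbon longer.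

Compound 4, `CC(=O)SCC(=O)c1ccc(NS(=O)(=O)c2ccc(OCCCN3CCCC3)cc2)nc1`, arises from compound 3 by the change (2-(pyrrolidin-1-yl)ethyl in place of pyridin-2-yl on a saturated chain carbon bound to an oxygen on an aromatic ring). Among the measured compounds shown here, one measured step bears on this: an 8.0-fold lower number from compound 1 to compound 2 (0.90 log units; beyond the scatter), where a pyridin-2-yl-bearing chain gave way to a saturated ring holding a nitrogen. The change from compound 3 to compound 4 likewise trades a six-membered aromatic ring with one hetero atom for a five-membered non-aromatic ring with one hetero atom. A step of similar direction, a lower number, is expected in this assay, though its size rests on a single comparison and on a starting point that was never measured. Compound 4 is estimated at 1500 nM, within a range of 300 nM to 8000 nM.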

Compound 4, half-maximal effective concentration: 400 nM
Compound 4: the middle estimate sits 3.8-fold (0.57 log units) above what was measured; low and high end bracket the measured number.
By their numbers in this assay, from the lowest: compound 4; then compound 2; then compound 1.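

In this assay, compound 4 has the lowest number of the three compounds with values, with a 3.0-fold lower number from compound 2 to compound 4 (0.48 log units; beyond the scatter) and a 24-fold lower number from compound 1 to compound 4 (1.38 log units; beyond the scatter), both beyond the usual scatter. A saturated ring holding a nitrogen, until now seen only as the 1-methylpiperidin-3-yl of compound 2, thus also goes with a lower number when it sits at the end of an open chain, as the 3-(pyrrolidin-1-yl)propyl of compound 4. No supporting measurement is available to explain these lower numbers.

On these data alone, with no number for compound 3, the effect of going from its (pyridin-2-yl)methyl to the 3-(pyrrolidin-1-yl)propyl of compound 4 remains unknown. Also open, as far as these compounds go, is whether the ring or the chain length matters more, a question that a 2-(pyrrolidin-1-yl)ethyl chain or a piperidin-1-yl ring on the same propyl chain could help to answer.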